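Aryl exchange on the ring nitrogen: toward compound 4

A few compounds are considered here, and "the series" means these few. Any claim that something is new, unique, unknown or untested is made for them only; others in the source may bear on it.

Three measured compounds of the series differ only in the aryl group on an aromatic nitrogen of the shared core. Compound 1 `CC1(C)[C@H]2CC[C@]1(C)N(Cc1cn(-c3cccc(Cl)c3)nn1)C(=O)C2` gives 510 nM in a functional assay on SGC-7901 cells (Homo sapiens) for inhibition, read by MTT assay, with a stated time of 24 h; on this read-out higher numbers stand for weaker inhibition and lower numbers for stronger inhibition. Compound 2 `CC1(C)[C@H]2CC[C@]1(C)N(Cc1cn(-c3ccccc3Br)nn1)C(=O)C2` gives 500 nM in this assay, and compound 3 `COc1cccc(-n2cc(CN3C(=O)C[C@@H]4CC[C@@]3(C)C4(C)C)nn2)c1` gives 590 nM. Compound 1 stands second highest of the three numbers; its nearest neighbour is compound 2 and its furthest is compound 3, with both gaps within the scatter: a 1.0-fold lower number from compound 1 to compound 2 (0.01 log units; within the scatter) and a 1.2-fold higher number from compound 1 to compound 3 (0.06 log units; within the scatter). The remaining pair is likewise close, a 1.2-fold higher number from compound 2 to compound 3 (0.07 log units; within the scatter).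

Compound 4 `CC1(C)[C@H]2CC[C@]1(C)N(Cc1cn(-c3ccc(O)cc3)nn1)C(=O)C2` is not yet measured. It differs from compound 1 in one place: 4-hydroxyphenyl in place of 3-chlorophenyl on an aromatic nitrogen. For the measured compounds named here, the steps that bear on this change are the aryl exchanges already seen, a 1.0-fold lower number from compound 1 to compound 2 (0.01 log units; within the scatter), a 1.2-fold higher number from compound 1 to compound 3 (0.06 log units; within the scatter) and a 1.2-fold higher number from compound 2 to compound 3 (0.07 log units; within the scatter), none of them beyond the scatter in this assay. On that basis no step beyond the scatter is expected here either. Going by the values given here, the 4-hydroxyphenyl group does bring a hydrogen-bond donor and a hydrogen-bond acceptor that no measured compound carries, which widens the range rather than shifting the middle. Compound 4 is therefore expected near 550 nM, between 250 nM and 1300 nM, an expected step of a 1.1-fold higher number from compound 1 to compound 4 (0.03 log units; within the scatter).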

Compound 4, half-maximal inhibitory concentration: 330 nM
Compound 4: the middle estimate sits 1.7-fold (0.22 log units) above what was measured; measured number inside the range.
By their numbers in this assay, from the lowest: compounds 4, 2, 1 and 3 (each within the scatter of the next).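

On the aromatic nitrogen, 4-hydroxyphenyl is the only group shown that carries a hydrogen-bond donor and a hydrogen-bond acceptor, and in this assay its exchange for 3-chlorophenyl reads a 1.5-fold lower number from compound 1 to compound 4 (0.19 log units; within the scatter) and stays inside the scatter. The exchanges against the other two aryl groups read a 1.5-fold lower number from compound 2 to compound 4 (0.18 log units; within the scatter) and a 1.8-fold lower number from compound 3 to compound 4 (0.25 log units; within the scatter) and are wider than any step among compounds 1, 2 and 3, yet neither lies beyond the scatter. The position therefore shows no step beyond the scatter across the chloro, bromo and methoxy aryl groups, and that still holds once a hydroxyl-bearing aryl group enters.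

Going by these compounds, whether an amine or a carboxylic acid on the aryl ring, or a longer chain in place of the aryl group, would give a step beyond the scatter remains open. No measurement at hand accounts for the size of these steps.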